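A few compounds are considered here, and "the series" means these few. Any claim that something is new, unique, unknown or untested is made for them only; others in the source may bear on it.

Measured compounds in a functional assay on HL-60 cells (Homo sapiens) for antiproliferative activity, read by XTT assay, with a stated time of 72 h; on this read-out lower numbers stand for stronger inhibition and higher numbers for weaker inhibition:
Compound 1 `Cc1nc(N)c2c(-c3ccco3)cn([C@@H]3O[C@H](CO)[C@@H](O)[C@H]3O)c2n1` gives > 20000 nM, a limit of the assay and not a number.
Compound 2 `Cc1nc(N)c2c(-c3cc4ccccc4o3)cn([C@@H]3O[C@H](CO)[C@@H](O)[C@H]3O)c2n1` gives > 20000 nM, likewise a limit.
Going by the values given here, compound 3 `CNc1ncnc2c1c(-c1cc3ccccc3o1)cn2[C@@H]1O[C@H](CO)[C@@H](O)[C@H]1O` gives 8950 nM, the only number among the three.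

Compound 2 and compound 1 differ by furan-2-yl in place of 1-benzofuran-2-yl on an aromatic carbon. The step that the two limits leave unreadable from compound 2 to compound 1 cannot be read, since the limit of > 20000 nM in this assay, at which 2 of the 3 values shown sit, marks where both values sit. Compound 3 has the same atoms as compound 2 joined differently; the difference between the two cores is not broken down here. Compound 4 `CNc1ncnc2c1c(-c1ccco1)cn2[C@@H]1O[C@H](CO)[C@@H](O)[C@H]1O` is not yet measured in this assay; it differs from compound 3 by furan-2-yl in place of 1-benzofuran-2-yl on an aromatic carbon, the same change as that from compound 2 to compound 1, with the place described in identical words. With the earlier step unreadable, little guides the size. Compound 3 gives 8950 nM, the weakest number that can be read here. That number is not far from the limit of > 20000 nM in this assay, at which 2 of the 3 values shown sit. Compound 4 is expected to land in the same region, a step of a 1.8-fold higher number from compound 3 to compound 4 (0.25 log units; within the scatter). Compound 4 is estimated at 16000 nM, within 6000 nM and 45000 nM.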

Compound 4, half-maximal inhibitory concentration: 620 nM
Compound 4: middle estimate off by 26-fold (1.41 log units), on the high side; measured number below the stated range.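

In this assay, furan-2-yl in place of 1-benzofuran-2-yl on the core of compound 3 gives a 14-fold lower number from compound 3 to compound 4 (1.16 log units; beyond the scatter), a large step beyond the scatter. The same change from compound 2 to compound 1 cannot be read, as the values on that core are limits of the assay and not numbers: the limit of > 20000 nM in this assay, at which 2 of the 4 values shown sit. The size of the change is therefore shown on one core only, and the compounds do not show whether it carries over to the other core.

The compounds shown leave open how a thiophen-2-yl or a phenyl group would fare in place of furan-2-yl on the core of compound 4. They also leave open whether an ethyl or a longer alkyl chain on the amine nitrogen would keep the value of compound 4.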